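The source may hold more compounds than are shown below. What is called first, only, known or untested is meant among the compounds shown, and "the series" means these compounds.

The shared core appears in compound 1 `CC(C)n1ncc2c(C(=O)Nc3ccccc3)cccc21`, compound 2 `CC(C)n1ncc2c(C(=O)NCc3ccccc3)cccc21` and compound 3 `Cc1ccc(-n2cc(CNC(=O)c3cccc4c3cnn4C(C)C)nn2)c(C)c1`. In a functional assay on MCF7 cells (Homo sapiens) for inhibition, read by MTT assay, with a stated time of 72 h (on this read-out higher numbers stand for weaker inhibition and lower numbers for stronger inhibition), compound 1 gives 19700 nM. Compound 2 in this assay reaches only a limit, > 40000 nM, not a number. The step of an at least 2.0-fold higher number from compound 1 to compound 2 (0.30 log units; that floor lies within the scatter) therefore has a floor that lies inside the usual scatter. Compound 3 in this assay likewise reaches only a limit, > 40000 nM. Two of the three values thus sit at the limit of > 40000 nM in this assay, at which 2 of the 3 values shown sit, and compound 3 stands among the compounds for which this assay reports no number; no step from compound 3 to any other compound can be sized from what is shown.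

Compound 4 `CC(C)n1ncc2c(C(=O)NCc3cn(-c4cccc(F)c4)nn3)cccc21` differs from compound 3 in one place: 3-fluorophenyl in place of 2,4-dimethylphenyl on an aromatic nitrogen. Within the data shown here, no measured step touches this position; the only measured step, an at least 2.0-fold higher number from compound 1 to compound 2 (0.30 log units; that floor lies within the scatter), concerns the amide-type nitrogen, not the aromatic nitrogen, so it gives no direction for this change. For compound 4 the expected result in this assay is 40000 nM, with a range from 15000 nM to 100000 nM. The step from compound 3 to compound 4 is expected to be a number no higher from compound 3 to compound 4 (the limit leaves the size open), nothing beyond the scatter, and most likely again only a limit.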

Compound 4, half-maximal inhibitory concentration: > 40000 nM
Compound 4 was reported as a limit; the forecaster's own chance of this, stated with the estimate: 70%; the middle value sits exactly at the limit.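

No step from compound 3 to compound 4 can be read in this assay, because each of the two compounds gives only a limit and not a number: the limit of > 40000 nM in this assay, at which 3 of the 4 values shown sit.

The compounds shown leave open whether 3-fluorophenyl and 2,4-dimethylphenyl on the aromatic nitrogen differ at all in this assay, and whether any group at that place would give a measurable number.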